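This account rests on a few compounds, and the source may have more. Where it says the series, first, only, none or still open, it means among the compounds named here.

Compound 1 `CCCCN(CC)c1nc(C)nc2c1nnn2-c1c(Br)cc(OC)cc1OC` and compound 2 `CCCCN(CC)c1nc(C)nc2c1nnn2-c1c(Cl)cc(OC)cc1OC` share one core and differ in a single place. In an in vitro assay on 293-EBNA cells for binding affinity to corticotropin-releasing factor receptor 1 (Homo sapiens) (a lower number here means a stronger inhibitor, a higher number a weaker inhibitor), compound 1 gives 3 nM and compound 2 gives 4.4 nM. The change between them is chloro in place of bromo on an aromatic carbon, and it made the step of a 1.5-fold higher number from compound 1 to compound 2 (0.17 log units; within the scatter). Compound 3 `CCCCN(CC)c1nc(C)nc2c1ncn2-c1c(Br)cc(OC)cc1OC` carries a different core; how the core of compound 3 differs from the core of compound 1 is not broken down here. In this assay compound 3 gives 3.5 nM, and what its value and the values of compound 1 and compound 2 show is that all three sit close together. Compound 4 `CCCCN(CC)c1nc(C)nc2c1ncn2-c1c(Cl)cc(OC)cc1OC` has not yet been measured. It differs from compound 3 by chloro in place of bromo on an aromatic carbon, the same change that separates compound 1 from compound 2, made at a place described in the same words. Going by the values given here, since the one earlier instance of this change, a 1.5-fold higher number from compound 1 to compound 2 (0.17 log units; within the scatter), stayed within the scatter, the step is expected to be a 1.4-fold higher number from compound 3 to compound 4 (0.15 log units; within the scatter). Compound 4 is therefore estimated to give 5 nM in this assay, with a likely range from 2.5 nM to 10 nM. Among the compounds with values here, this estimate rests on compound 3, which gives 3.5 nM, shifted by the single earlier step of a 1.5-fold higher number from compound 1 to compound 2 (0.17 log units; within the scatter).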

Compound 4, inhibition constant: 5.2 nM
Compound 4: the middle estimate sits 1.0-fold (0.02 log units) below what was measured; the measured number falls inside the stated range.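

Chloro in place of bromo on the core of compound 3 gives a 1.5-fold higher number from compound 3 to compound 4 (0.17 log units; within the scatter) in this assay, and the step can be set directly beside the earlier one on the core of compound 1: the same change on two cores in this assay, a 1.5-fold higher number (0.17 log units; within the scatter) from compound 1 to compound 2 and a 1.5-fold higher number (0.17 log units; within the scatter) from compound 3 to compound 4, 1.0-fold (0.01 log units) apart, within the scatter of two such steps. So in this series the change carried from one core to the other with no difference that can be told from the scatter, and the bromo and chloro compounds stay close together on both cores. It does not show that chloro and bromo truly differ, since each step lies within the scatter, and two cores with one pair each are too few to say how the change would behave on any further core.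

The compounds shown leave open whether fluoro, trifluoromethyl or a nitrile in the same place would stay as close to bromo and chloro. They also leave open how the values would move with a longer chain on the amine, or with a hydroxyl in place of either methoxy group.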